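Replacing a tert-butylphenyl group with nitrofuran on the ring amine

The source may hold more compounds than are shown below. What is called first, only, known or untested is meant among the compounds shown, and "the series" means these compounds.

Measured compounds:
compound 1 `CCc1nc2cc(Cl)ccn2c1C(=O)NCc1ccc2c(c1)CCN(Cc1ccc(OC)cc1)C2` — 32 ug/mL
compound 2 `CCc1nc2cc(Cl)ccn2c1C(=O)NCc1ccc2c(c1)CCN(Cc1cc(F)cc(F)c1)C2` — 48 ug/mL
compound 3 `CCc1nc2cc(Cl)ccn2c1C(=O)NCc1ccc2c(c1)CCN(Cc1ccc(C(C)(C)C)cc1)C2` — 14 ug/mL

Three compounds sharing one core were tested in an ADME assay on Vero cells (Chlorocebus sabaeus) for cytotoxicity, read by MTT assay, with a stated time of 72 h; on this read-out higher numbers stand for lower toxicity in this test and lower numbers for higher toxicity in this test. Compound 1 gives 32 ug/mL, compound 2 gives 48 ug/mL and compound 3 gives 14 ug/mL. On these numbers compound 3 stands lowest of the three: the step of a 2.3-fold lower number from compound 1 to compound 3 (0.36 log units; beyond the scatter) and the step of a 3.4-fold lower number from compound 2 to compound 3 (0.54 log units; beyond the scatter) both lie beyond the scatter, while a 1.5-fold higher number from compound 1 to compound 2 (0.18 log units; within the scatter) does not.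

Compound 4 `CCc1nc2cc(Cl)ccn2c1C(=O)NCc1ccc2c(c1)CCN(Cc1ccc([N+](=O)[O-])o1)C2` is not yet measured in this assay. It differs from compound 3 by 5-nitrofuran-2-yl in place of 4-(tert-butyl)phenyl on a saturated chain carbon bound to an amine nitrogen in a ring. The two steps that bear on this change are those in which the tert-butyl-bearing group was introduced, a 2.3-fold lower number from compound 1 to compound 3 (0.36 log units; beyond the scatter) and a 3.4-fold lower number from compound 2 to compound 3 (0.54 log units; beyond the scatter); in both, the arrival of that group went with a lower number. Among the measured compounds shown here, removing it is therefore expected to move the number back upward by a modest amount in this assay, though no measured compound carries a nitrofuran group, so the size is uncertain. The expected step is a 2.1-fold higher number from compound 3 to compound 4 (0.33 log units; beyond the scatter). Compound 4 is estimated at 30 ug/mL, within a range from 12 ug/mL to 75 ug/mL.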

Compound 4, half-maximal cytotoxic concentration: > 64 ug/mL
Compound 4: only a limit was reported; the forecaster's own chance of this, stated with the estimate: 5%; at least 2.1-fold (0.32 log units) between middle value and limit.
By their numbers in this assay, from the lowest: compound 3; then compounds 1 and 2 (each within the scatter of the next). At a limit, above all of these: compound 4.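

Compound 4 gives only a limit, > 64 ug/mL, in this assay. Even so, 5-nitrofuran-2-yl in place of 4-(tert-butyl)phenyl, on a saturated chain carbon bound to an amine nitrogen in a ring, gives an at least 4.5-fold higher number from compound 3 to compound 4 (0.66 log units; beyond the scatter), so this change raises the number beyond the scatter, and on this read-out a higher number stands for lower toxicity in this test. The other two steps, an at least 2.0-fold higher number from compound 1 to compound 4 (0.30 log units; that floor lies within the scatter) and an at least 1.3-fold higher number from compound 2 to compound 4 (0.12 log units; that floor lies within the scatter), have floors that lie within the scatter, so neither can be read as a real difference.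

The compounds shown do not separate the furan ring from the nitro group, which a plain furan or a nitrophenyl group at this position could do. They also leave open how far the number of compound 4 lies past its limit.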